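The source may report more compounds than this note shows. Statements on the series, on what has been measured and on what is new or still open speak of the compounds shown alone.

Among the measured compounds shown here, in an assay on isolated protein for inhibition of Rho-associated protein kinase 2 (Homo sapiens), read by scintillation counting, radiometric assay and 33P incorporation, with a stated time of 40 min, in the presence of a further agent that is not named here (on this read-out lower numbers stand for stronger inhibition and higher numbers for weaker inhibition), compound 1 `O=C(COc1ccc2c(=O)ccoc2c1)Nc1cccc(NC(=O)c2ccc(F)cc2)c1` gives 54 nM, and compound 2 `N#Cc1ccc(C(=O)Nc2cccc(NC(=O)COc3ccc4c(=O)ccoc4c3)c2)cc1` gives 15 nM; the only measured step, a 3.6-fold lower number from compound 1 to compound 2 (0.56 log units; beyond the scatter), concerns the end of the benzamide. Compound 3 `Cc1cc(NC(=O)COc2ccc3c(=O)ccoc3c2)cc(NC(=O)c2ccc(N(C)C)cc2)c1` stands apart: in this assay compound 3 reaches only the limit of > 10000 nM, which is a limit of the assay and not a number, as noted at the limit of > 10000 nM in this assay, at which 1 of the 3 values shown sits. Compound 4 `CN(C)c1ccc(C(=O)Nc2cc(Br)cc(NC(=O)COc3ccc4c(=O)ccoc4c3)c2)cc1` differs from compound 3 by bromo in place of methyl on an aromatic carbon. No measured step touches this position, so nothing shown speaks for a move in either direction. Starting from a limit, the step that the limit leaves unreadable from compound 3 to compound 4 is expected to leave compound 4 likely beyond reach as well, with an estimate in this assay of 15000 nM, between 3000 nM and 60000 nM.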

Compound 4, half-maximal inhibitory concentration: 4560 nM
Beside the measured number, compound 4's estimate is 3.3-fold (0.52 log units) above it; the measured number falls inside the stated range.
By their numbers in this assay, from the lowest: compound 2; then compound 1; then compound 4. At a limit, above all of these: compound 3.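

Among the compounds shown here, for the first time, a measured step touches this position: in this assay, bromo in place of methyl on this aromatic carbon comes with an at least 2.1-fold lower number from compound 3 to compound 4 (0.34 log units; beyond the scatter). The group here therefore matters to the read-out, even with the benzamide end unchanged. The true size of the step stays unknown since compound 3 sits at a limit of the assay, not at a number: the limit of > 10000 nM in this assay, at which 1 of the 4 values shown sits.

The compounds shown leave open how chloro, a methoxy group or an amine on this carbon would read. Also open, going by these compounds, is whether bromo here would give a similar step alongside the benzamide ends of compound 1 and compound 2.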